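A few compounds are considered here, and "the series" means these few. Any claim that something is new, unique, unknown or untested is made for them only; others in the source may bear on it.

Of the compounds shown here, three built on one shared core have been measured in an assay on isolated protein with dual specificity calcium/calmodulin-dependent 3',5'-cyclic nucleotide phosphodiesterase 1B (Bos taurus) as the target, tested at 100 uM; on this read-out higher numbers stand for more inhibition at the one concentration tested (going by the name of the read-out) and lower numbers for less inhibition. Compound 1 `Cn1c(N)nc2c1c(=O)n(CC1CC1)c(=O)n2CC1CC1` gives 30%, compound 2 `Nc1nc2c(c(=O)n(CC3CC3)c(=O)n2CC2CC2)n1Cc1ccc([N+](=O)[O-])cc1` gives 30%, and compound 3 `Nc1nc2c(c(=O)n(CC3CC3)c(=O)n2CC2CC2)n1S(=O)(=O)c1ccc(C(F)(F)F)cc1` gives 0%. Compound 3 therefore stands lowest of the three, sitting beyond the scatter below both compound 1 and compound 2. Within the data shown here, the only step between compounds that differ in a single place is no change at the digits printed from compound 1 to compound 2 (within the scatter); it concerns a different part of the molecule and does not bear on the change at hand. Compound 4 `COc1ccc(S(=O)(=O)n2c(N)nc3c2c(=O)n(CC2CC2)c(=O)n3CC2CC2)cc1` differs from compound 3 by methoxy in place of trifluoromethyl on an aromatic carbon. Among the measured compounds shown here, no measured pair tests a swap on this six-membered carbon ring, so there is nothing to point toward either a rise or a fall. The step of a number 8 percentage points higher from compound 3 to compound 4 (within the scatter) is therefore expected to stay within the scatter, with compound 4 remaining near the bottom. Compound 4 is estimated at 8%, within a range of 0% to 25%.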

Compound 4, a percentage reported as inhibition, at one concentration (the size of the read-out at that concentration, not a potency): 25%
Beside the measured number, compound 4's estimate is 17 percentage points below it, and the stated range covers the measured number.
By their numbers in this assay, from the lowest: compound 3; then compounds 4, 1 and 2 (each within the scatter of the next).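

In this assay, among these compounds, methoxy in place of trifluoromethyl on the six-membered aromatic ring, para to a large group, gives a number 25 percentage points higher from compound 3 to compound 4 (beyond the scatter), the first single-place change that moves the number beyond the scatter. This shows that the group at this ring carbon matters to the read-out, even at the one concentration tested, although the step is modest. The swap replaces a group of 4 heavy atoms and no hydrogen-bond acceptor with one of 2 heavy atoms and 1 hydrogen-bond acceptor, but nothing measured here gives a reason for the step.

As far as these compounds go, with only these two groups compared at this carbon, it stays open where a hydroxyl, an amine or a chlorine would fall. From the compounds shown here alone, it is also open whether the same swap would have a similar effect on the ring of compound 2.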